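The compounds below may be only part of what the source reports. "The series", "measured", "known", "first", "only" and "open" are said of these compounds alone.

Compound 1 `C=CC(=O)Nc1cccc(NC(=O)CSc2nc(Nc3ccccc3)c3ccccc3n2)c1` and compound 2 `O=C(CSc1nc(Nc2ccccc2)c2ccccc2n1)Nc1ccc(F)cc1` share a core and differ only in the amide-bearing aryl group. In a functional assay on MDA-MB-231 cells (Homo sapiens) for inhibition, read by MTT assay, with a stated time of 72 h (a lower number here means a stronger inhibitor, a higher number a weaker inhibitor), compound 1 gives 10200 nM, while compound 2 gives 34100 nM, the higher of the two numbers; that single step, a 3.3-fold higher number from compound 1 to compound 2 (0.52 log units; beyond the scatter), swaps an amide-type nitrogen substituent and is of modest size.

Compound 3 `O=C(CSc1nc(Nc2ccccc2)c2ccccc2n1)Nc1ccc(C(F)(F)F)cc1` is the next compound, not yet measured in this assay. The change from compound 2 is trifluoromethyl in place of fluoro on an aromatic carbon, sitting para to a large group on the same six-membered aromatic ring of carbon only. For the measured compounds named here, no measured step touches that position: the only step available alters a different part of the molecule, so nothing here argues for a change beyond the scatter in either direction.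

Compound 3 is therefore expected to come out near compound 2, at about 30000 nM, within 10000 nM to 100000 nM. The expected step, a 1.1-fold lower number from compound 2 to compound 3 (0.06 log units; within the scatter), is an estimate within the scatter.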

Compound 3, half-maximal inhibitory concentration: 11100 nM
Beside the measured number, compound 3's estimate is 2.7-fold (0.43 log units) above it; the measured number falls inside the stated range.
By their numbers in this assay, from the lowest: compounds 1 and 3 (each within the scatter of the next); then compound 2.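

For the compounds shown here, the position para to a large group on the aromatic ring, which no earlier step had touched, does respond in this assay: trifluoromethyl in place of fluoro gives a 3.1-fold lower number from compound 2 to compound 3 (0.49 log units; beyond the scatter), a modest step. The second new comparison, a 1.1-fold higher number from compound 1 to compound 3 (0.04 log units; within the scatter), shows that a compound without the 3-((vinylcarbonyl)amino)phenyl group can match compound 1 in this assay, so among these three compounds that group is not required for a number of this size. Nothing available explains either step.

The compounds shown leave open how other groups at this position, such as a methoxy group, an amine or a carboxylic acid, would read. They also leave open whether trifluoromethyl would give a step of similar size with a different group on the other amine nitrogen of the shared core.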